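Pyridyl chalcones: methyl for chloro on the aryl ketone

The source may hold more compounds than are shown below. What is called first, only, known or untested is meant among the compounds shown, and "the series" means these compounds.

Values in a functional assay with Rattus norvegicus as the target (a lower number here means a stronger inhibitor, a higher number a weaker inhibitor), so far:
compound 1 `O=C(/C=C/c1ccncc1)c1ccccc1`: 49000 nM
compound 2 `O=C(/C=C/c1ccncc1)c1cccc(Cl)c1`: 69000 nM
compound 3 `C(=C/c1noc2ccccc12)\c1ccncc1`: > 100000 nM

Compound 3 gives only a limit of the assay, not a number. Among the two numbers, compound 2 has the higher one, but its nearest neighbour is compound 1, and the step of a 1.4-fold higher number from compound 1 to compound 2 (0.15 log units; within the scatter) stays within the scatter, so the two cannot be ordered.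

The compound still to be measured is compound 4 `Cc1cccc(C(=O)/C=C/c2ccncc2)c1`. It differs from compound 2 by methyl in place of chloro on an aromatic carbon. Going by the values given here, the only measured step that bears on this position is a 1.4-fold higher number from compound 1 to compound 2 (0.15 log units; within the scatter), which shows that putting chloro onto hydrogen at this place hardly moved the number. Exchanging that chloro for methyl, a group of the same single heavy atom, is expected to move it no further: the expected step from compound 2 to compound 4 in this assay is a 1.2-fold lower number from compound 2 to compound 4 (0.06 log units; within the scatter), within the scatter. For compound 4 the estimate is therefore 60000 nM, with a range from 25000 nM to 150000 nM. The upper end of that range for compound 4 approaches (the limit of > 100000 nM in this assay, at which 1 of the 3 values shown sits), so a limit instead of a number cannot be excluded.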

Compound 4, half-maximal inhibitory concentration: 39000 nM
For compound 4 the middle estimate is 1.5-fold (0.19 log units) above the measured one; low and high end bracket the measured number.
By their numbers in this assay, from the lowest: compounds 4, 1 and 2 (each within the scatter of the next). At a limit, above all of these: compound 3.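

In this assay, the exchange at this place gives a 1.8-fold lower number from compound 2 to compound 4 (0.25 log units; within the scatter), and the comparison with the unsubstituted parent gives a 1.3-fold lower number from compound 1 to compound 4 (0.10 log units; within the scatter). Until now only chloro had been seen on this aromatic carbon, meta to a large group. With methyl added, hydrogen, chloro and methyl all lie within the scatter of one another, so no order can be set among the three and this place shows no response to any of these substitutions so far. Compound 3 stays the only compound at a limit of the assay, while compound 4 gives a number: the limit of > 100000 nM in this assay, at which 1 of the 4 values shown sits.

Chloro and methyl each count one heavy atom, so the compounds shown leave open whether anything larger or charged at this place, such as an amine, a carboxylic acid or a longer chain, would move the number beyond the scatter in this assay. They also leave open whether methyl or chloro on another carbon of the same ring would behave as they do here, and whether any change to the shared core could give a clearly lower number.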